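The source may report more compounds than this note shows. Statements on the series, on what has been measured and on what is new or still open speak of the compounds shown alone.

Compound 1 `CC(=O)OCCc1c(C)nc(Cl)nc1Cl` carries an acetoxy group on its side chain. In a functional assay on MOLT-4 cells (Homo sapiens) for antiproliferative activity, read by MTT assay, with a stated time of 24 h (on this read-out higher numbers stand for weaker inhibition and lower numbers for stronger inhibition), compound 1 gives > 100000 nM, which is a limit of the assay and not a number; the same applies to the limit of > 100000 nM in this assay, at which 1 of the 3 values shown sits. Compound 3 `Cc1nc(Cl)nc(Cl)c1CCCl` keeps the core of compound 1; in this assay compound 3 gives 5000 nM. For the measured compounds named here, the one change between them is chloro in place of acetoxy on a saturated chain carbon, two bonds along the chain from an aromatic carbon, and it produces an at least 20-fold lower number from compound 1 to compound 3 (1.30 log units; beyond the scatter).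

Compound 2 `COc1nc(C)c(CCOC(C)=O)c(OC)n1` has a different core; the difference between the two cores is not broken down here. In this assay compound 2 is recorded as "not determined" (no result reported), so no number stands for it. Compound 4 `COc1nc(C)c(CCCl)c(OC)n1` is made from compound 2 by the same change, namely (chloro in place of acetoxy on a saturated chain carbon, two bonds along the chain from an aromatic carbon), so the change occurs twice among the compounds shown.

Compound 4 thus carries the chloro group of compound 3 on the core of compound 2. Going by the values given here, the expectation for compound 4 rests on compound 3 and its value of 5000 nM together with the step of an at least 20-fold lower number from compound 1 to compound 3 (1.30 log units; beyond the scatter), but compound 2 gives no number from which a matching step could be read, and no other compound on the core of compound 2 has a measured value. The estimate for compound 4 is therefore held wide: in this assay compound 4 is expected to give around 40000 nM, somewhere between 5000 nM and 200000 nM, with a real chance that only a limit is reported.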

Compound 4, half-maximal inhibitory concentration: > 100000 nM
Compound 4: no number, only a limit; the forecaster's own chance of this, stated with the estimate: 45%; middle value at least 2.5-fold (0.39 log units) from the limit.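

In this assay compound 4 gives > 100000 nM, which is a limit of the assay and not a number. For the compounds shown here, compound 2 has no reported result, so no step from compound 2 to compound 4 can be read. The compounds shown leave open whether chloro in place of acetoxy changes the number on the core of compound 2 as it does on the core of compound 1, and where compound 4 truly stands, given this result: the limit of > 100000 nM in this assay, at which 2 of the 4 values shown sit.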